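From furan-2-yl to 3-chlorophenyl on the shared core

A few compounds are considered here, and "the series" means these few. Any claim that something is new, unique, unknown or untested is made for them only; others in the source may bear on it.

Values measured in a functional assay on MCF7 cells (Homo sapiens) for cytotoxicity, read by ELISA, with a stated time of 4 days (a lower number here means a stronger inhibitor, a higher number a weaker inhibitor), are these:
- Compound 1 `Cc1ccsc1-c1cc(-c2ccco2)cc(-c2ccc(Cl)cc2)n1` gives 890 nM here
- Compound 2 `Cc1ccsc1-c1cc(-c2ccoc2)cc(-c2ccco2)n1` gives 18300 nM here
- Compound 3 `Cc1ccsc1-c1cc(-c2ccc(Cl)o2)cc(-c2ccco2)n1` gives 5570 nM here

Compound 3 stands second highest of the three numbers, below compound 2 and above compound 1. Compound 4 `Cc1ccsc1-c1cc(-c2ccc(Cl)o2)cc(-c2cccc(Cl)c2)n1` brings one change, 3-chlorophenyl in place of furan-2-yl on an aromatic carbon (3-chlorophenyl in place of furan-2-yl, next to the ring nitrogen). For the measured compounds named here, the one measured step, a 3.3-fold lower number from compound 2 to compound 3 (0.52 log units; beyond the scatter), lies at another place and bears only indirectly. Compound 1 also has a six-membered aromatic ring of carbon only at that place and gives 890 nM as its number, but it differs from compound 3 elsewhere too, so it is a loose guide. A step of a 3.5-fold lower number from compound 3 to compound 4 (0.54 log units; beyond the scatter) is expected in this assay on this basis. For compound 4 the estimated value is 1600 nM, with an expected range from 550 nM to 4500 nM.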

Compound 4, half-maximal inhibitory concentration: 18800 nM
The estimate for compound 4 lay 12-fold (1.07 log units) below the measured number; measured number outside the range, above it.
By their numbers in this assay, from the lowest: compound 1; then compound 3; then compounds 2 and 4 (each within the scatter of the next).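

At the place next to the ring nitrogen, with the 5-chlorofuran-2-yl group held in the molecule, this assay gives a 3.4-fold higher number from compound 3 to compound 4 (0.53 log units; beyond the scatter) when 3-chlorophenyl replaces furan-2-yl. For the compounds shown here, this is the first direct reading at this place, and on this core the furan-2-yl group is the better of the two by a margin beyond the scatter. No measurement offered here explains the step.

The compounds shown leave open whether the step follows from the six-membered ring or from its chlorine. A plain phenyl or a 4-chlorophenyl group at this place on the same core would separate the two.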